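This account rests on a few compounds, and the source may have more. Where it says the series, first, only, none or still open, it means among the compounds named here.

In a functional assay for inhibition, with Rattus norvegicus as the target (on this read-out higher numbers stand for weaker inhibition and lower numbers for stronger inhibition), compound 1 (`CC(/N=c1\c(O)c(O)\c1=N/c1ccc(S(N)(=O)=O)cc1)C(C)(C)C`) gives > 30000 nM, which is a limit of the assay and not a number. Among the measured compounds shown here, compound 2 (`Cc1cc(C#N)ccc1/N=c1\c(O)c(O)\c1=N/[C@H](C)C(C)(C)C`) reads 1080 nM, the only actual number so far, so it cannot yet be ranked against a second measured value. Compound 3 (`C[C@@H](/N=c1\c(O)c(O)\c1=N/c1ccc(C#N)cc1C(=O)c1ccccc1)C(C)(C)C`) differs from compound 2 at one place: benzoyl in place of methyl on an aromatic carbon. The benzoyl sits on an aromatic carbon, ortho to a large group and meta to a cyano group. For the measured compounds named here, no step between measured compounds is available to size such a change in this assay, so only a moderate weakening is expected, and its direction is uncertain. The estimated 2.3-fold higher number from compound 2 to compound 3 (0.36 log units; beyond the scatter) rests on a single anchor. That anchor is compound 2 with 1080 nM. For compound 3 the expected value is 2500 nM, with an estimated range of 400 nM to 15000 nM.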

Compound 3, half-maximal inhibitory concentration: 4780 nM
Estimate against measurement, compound 3: 1.9-fold (0.28 log units) below, and the stated range covers the measured number.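

Benzoyl in place of methyl on an aromatic carbon gives a 4.4-fold higher number from compound 2 to compound 3 (0.65 log units; beyond the scatter) in this assay and this is the first readable step at this place, ortho to a large group and meta to a cyano group. The position takes benzoyl, with its 8 heavy atoms and one six-membered aromatic ring, at a modest loss of inhibition, and compound 3 still reads as a number and not as a limit. Both ends of the step are numbers, so its size can be read, while one value shown remains a limit of the assay: the limit of > 30000 nM in this assay, at which 1 of the 3 values shown sits.

This single step cannot separate the added ring from the carbonyl, and it gives no cause for the change. On these data alone, whether an amine or a carboxylic acid at this position would read closer to compound 2 or to compound 3 stays open.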